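A Methyl Group Added to Compound 2

This account rests on a few compounds, and the source may have more. Where it says the series, first, only, none or still open, it means among the compounds named here.

In a functional assay on HCT-116 cells (Homo sapiens) for antiproliferative activity, read by MTT assay, with a stated time of 48 h (a higher number here means a weaker inhibitor, a lower number a stronger inhibitor), compound 2 (`COc1ccc(-c2cc3c(cn2)[nH]c(=O)n3-c2cc(OC)c(OC)c(OC)c2)cc1`) gives 840 nM as the lower of the two numbers available. Compound 3 (`CCOc1ccc(-c2cc3c(cn2)[nH]c(=O)n3-c2cc(OC)c(OC)c(OC)c2)cc1F`) gives 7220 nM as the higher of them. Compound 1 (`COc1ccc(-c2cncc3[nH]c(=O)n(Cc4cc(OC)c(OC)c(OC)c4)c23)cc1`) stands at > 20000 nM as a limit of the assay. Compound 4 (`COc1ccc(-c2cc3c(cn2)[nH]c(=O)n3-c2cc(OC)c(OC)c(OC)c2)cc1C`) is unmeasured and carries methyl in place of hydrogen on an aromatic carbon, ortho to a methoxy group (methyl in place of hydrogen on an aromatic carbon). Going by an 8.6-fold higher number from compound 2 to compound 3 (0.93 log units; beyond the scatter) with 4-ethoxy-3-fluorophenyl in place of 4-methoxyphenyl, which is modest but beyond the scatter, a smaller step in the same direction is expected in this assay for this single methyl. The expected move is a 2.1-fold higher number from compound 2 to compound 4 (0.33 log units; beyond the scatter) towards weaker inhibition. For compound 4 the estimate is 1800 nM with an expected range of 600 nM to 6000 nM in this measurement.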

Compound 4, half-maximal inhibitory concentration: 1810 nM
Compound 4: middle estimate off by 1.0-fold (0.00 log units), on the low side; the range from low to high includes it.
By their numbers in this assay, from the lowest: compound 2; then compound 4; then compound 3. At a limit, above all of these: compound 1.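

In this assay, a single methyl on this aromatic carbon, ortho to a methoxy group, is enough to weaken the compound: a 2.2-fold higher number from compound 2 to compound 4 (0.33 log units; beyond the scatter). Set against the 4-ethoxy-3-fluorophenyl group, the 4-methoxy-3-methylphenyl group gives a 4.0-fold lower number from compound 3 to compound 4 (0.60 log units; beyond the scatter), so this methyl does not reach the number seen with compound 3.

On these data alone, how a hydroxyl, an amine or a longer chain would behave on this carbon remains open. Nothing available explains why the methyl shifts the number.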